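The source may report more compounds than this note shows. Statements on the series, on what has been measured and on what is new or still open speak of the compounds shown alone.

This study concerns positive allosteric modulators of a glutamate receptor, compared in an assay on HEK293 cells for positive allosteric modulation of metabotropic glutamate receptor 2 (Rattus norvegicus), read by thallium flux, with a stated time of 2.5 min; a higher number here means that more compound is needed for the effect, a lower number that less compound is needed. Among the measured compounds shown here, compound 1, with the structure `Cc1c(OCCCCOc2ccc(C(=O)O)cc2)ccc(C(=O)CC2CCCC2)c1O`, is the one compound with a number: in this assay compound 1 gives 824 nM. A close relative, compound 2 `Cc1c(OCCCCOc2ccc(C(=O)O)cc2)ccc(C(=O)CC2CCCC2)c1C`, belongs to the same set, but for compound 2 the outcome in this assay reads "not determined" (no result reported), so compound 1 stands alone as the only measured point, with nothing to be ranked above or below it.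

Compound 3, `Cc1cc(OCCCCOc2ccc(C(=O)CC3CCCC3)c(O)c2C)ccc1C(=O)O`, has not yet been measured. It differs from compound 1 in a single place: methyl in place of hydrogen on an aromatic carbon. For the measured compounds named here, no step between two measured compounds is available to show how large such a change tends to be, so any expectation rests on the single value of compound 1 alone. Because compound 1 gives 824 nM and the change adds only one methyl, the step of a 1.1-fold higher number from compound 1 to compound 3 (0.04 log units; within the scatter) is expected to stay within the usual scatter, in no clear direction. For compound 3 the value in this assay is therefore estimated at 900 nM, with a likely range from 300 nM to 2700 nM.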

Compound 3, half-maximal effective concentration: 564 nM
Beside the measured number, compound 3's estimate is 1.6-fold (0.20 log units) above it, within the range that was stated.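

In this assay, among the compounds shown here, the change from 4-carboxyphenyl to 4-carboxy-3-methylphenyl gives a 1.5-fold lower number from compound 1 to compound 3 (0.16 log units; within the scatter), and this is the first step that joins two compounds with numbers. It shows that the aromatic carbon ortho to a carboxy group can carry a methyl in place of hydrogen without moving the result outside the usual scatter of repeated measurements, so compound 1 and compound 3 cannot be told apart by this read-out. No separate measurement is available that bears on the reason for this outcome.

This is a single pair and a single small group, so it sets no rule for the series, and it cannot say whether the same carbon would give a similar result with an ethyl, a methoxy group or a chlorine atom in place of the methyl. It also leaves open whether a methyl on another carbon of the same ring, or a different acid such as a tetrazole in place of the carboxylic acid, would stay within the scatter of compound 1.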